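A few compounds are considered here, and "the series" means these few. Any claim that something is new, unique, unknown or untested is made for them only; others in the source may bear on it.

In a functional assay on HepG2 cells (Homo sapiens) for cytotoxicity, read by MTT assay, with a stated time of 72 h (on this read-out higher numbers stand for weaker inhibition and lower numbers for stronger inhibition), compound 1 `COc1ccc2ccc(=O)oc2c1C1=NN(C(N)=O)C(c2cccs2)C1` gives 26 nM. Two relatives share its core and differ only on the amine nitrogen in the ring: compound 2 `COc1ccc2ccc(=O)oc2c1C1=NNC(c2cccs2)C1` gives 11 nM, and compound 3 `COc1ccc2ccc(=O)oc2c1C1=NN(c2ccccc2)C(c2cccs2)C1` gives 15 nM. Measured from compound 1, the changes are a 2.4-fold lower number from compound 1 to compound 2 (0.37 log units; beyond the scatter) and a 1.7-fold lower number from compound 1 to compound 3 (0.24 log units; within the scatter), so compound 1 stands modestly apart from compound 2 only.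

Compound 4 `COc1ccc2ccc(=O)oc2c1C1=NN(C(N)=O)C(c2ccc(C)cc2)C1` has not yet been measured. It keeps the carbamoyl group of compound 1, and the change lies elsewhere: 4-methylphenyl in place of thiophen-2-yl on a saturated ring carbon. Going by the values given here, none of the measured steps touches this carbon, so they offer only indirect guidance. They show how far the numbers moved when the ring nitrogen changed, including a 1.4-fold higher number from compound 2 to compound 3 (0.13 log units; within the scatter), and all three compounds stay close together. The data contain no swap of the thiophen-2-yl group, so the size of this step is uncertain and the range must be wide. In this assay the expected step is a 1.5-fold higher number from compound 1 to compound 4 (0.19 log units; within the scatter), so no clear move beyond the scatter is expected. For compound 4 the estimated value is 40 nM, with an expected range of 12 nM to 180 nM.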

Compound 4, half-maximal inhibitory concentration: 46 nM
Compound 4: the middle estimate sits 1.2-fold (0.06 log units) below what was measured; the range from low to high includes it.
By their numbers in this assay, from the lowest: compounds 2, 3, 1 and 4 (each within the scatter of the next, the first and the last beyond it).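

Going by these compounds alone, compound 4 is the first compound here to change the saturated ring carbon next to the ring nitrogen, and in this assay putting 4-methylphenyl in place of thiophen-2-yl gives a 1.8-fold higher number from compound 1 to compound 4 (0.25 log units; within the scatter) while the carbamoyl group stays in place. For this pair, then, a five-membered aromatic ring with a sulfur atom can give way to a six-membered aromatic ring of carbon only, with a methyl group added, and the result does not move beyond the usual scatter; the sulfur-containing ring is not needed to keep the number in this range when the carbamoyl group is present. No measurement offered here bears on why this step has the size it has.

Going by these compounds, a single swap cannot separate the effect of the ring from that of its methyl group, so it remains open whether plain phenyl, or an aromatic ring bearing an amine or a carboxylic acid, would stay as close to compound 1 on this carbon. On these data alone, it is also open whether 4-methylphenyl would give a similar result with the hydrogen of compound 2 or the phenyl of compound 3 on the ring nitrogen.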